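Shifting a Hydroxyphenyl Group: Effect on Cell Inhibition

The source may report more compounds than this note shows. Statements on the series, on what has been measured and on what is new or still open speak of the compounds shown alone.

Compound 1 `Oc1cccc(-c2cc(-c3cccc(C(F)(F)F)c3)cc(-c3ccccc3O)n2)c1` — 6460 nM
Compound 2 `Oc1ccc(-c2cc(-c3cccc(C(F)(F)F)c3)cc(-c3ccccc3O)n2)cc1` — > 50000 nM
Compound 3 `Oc1cccc(-c2cc(-c3cccc(OC(F)(F)F)c3)cc(-c3cccc(O)c3)n2)c1` — > 50000 nM

In a functional assay on HCT-15 cells (Homo sapiens) for inhibition (on this read-out higher numbers stand for weaker inhibition and lower numbers for stronger inhibition), compound 1 gives 6460 nM. Compound 2 reaches only a limit of this assay, > 50000 nM. The change between them, (4-hydroxyphenyl in place of 3-hydroxyphenyl on an aromatic carbon), produced an at least 7.7-fold higher number from compound 1 to compound 2 (0.88 log units; beyond the scatter). Compound 3 also stops at a limit, > 50000 nM. Two of the three values sit at the limit of > 50000 nM in this assay, at which 2 of the 3 values shown sit. The difference between the core of compound 1 and the core of compound 3 is not broken down here.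

Compound 4 `Oc1ccc(-c2cc(-c3cccc(OC(F)(F)F)c3)cc(-c3cccc(O)c3)n2)cc1` has not yet been measured in this assay. Its relation to compound 3 is 4-hydroxyphenyl in place of 3-hydroxyphenyl on an aromatic carbon. This is the same kind of change as from compound 1 to compound 2, though the surroundings differ: in compound 1 the place is meta to a 2-hydroxyphenyl group and meta to a 3-(trifluoromethyl)phenyl group, whereas in compound 3 it is meta to a 3-hydroxyphenyl group and meta to a large group.

Given an at least 7.7-fold higher number from compound 1 to compound 2 (0.88 log units; beyond the scatter), the expectation is that the same kind of change weakens inhibition again or leaves it at a limit. Compound 4 is therefore expected at 120000 nM, within 40000 nM to 400000 nM. The step this expectation means is a step that the limit leaves unreadable from compound 3 to compound 4.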

Compound 4, half-maximal inhibitory concentration: 1730 nM
Estimate against measurement, compound 4: 69-fold (1.84 log units) above, outside the stated range (below it).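

In this assay, 4-hydroxyphenyl in place of 3-hydroxyphenyl gives an at least 28-fold lower number from compound 3 to compound 4 (1.46 log units; beyond the scatter), whereas the same change on the other core gives an at least 7.7-fold higher number from compound 1 to compound 2 (0.88 log units; beyond the scatter). The change therefore does not carry over between these two cores, as its direction reverses: the same change on two cores in this assay, an at least 7.7-fold higher number (0.88 log units; beyond the scatter) from compound 1 to compound 2 and an at least 28-fold lower number (1.46 log units; beyond the scatter) from compound 3 to compound 4, at least 220-fold (2.34 log units) apart, beyond the scatter of two such steps What this does not show is which of the differences between the two cores turns the step around, and the full size of each step stays unread, since one end of each sits at a limit of the assay: the limit of > 50000 nM in this assay, at which 2 of the 4 values shown sit.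

The compounds shown leave open whether the reversal follows the swap of trifluoromethyl for trifluoromethoxy on the phenyl group or the place of the hydroxyl on the other hydroxyphenyl group. They also leave open how the step would run with an amine or a carboxylic acid in place of the hydroxyl on the 4-hydroxyphenyl group.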